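The compounds below may be only part of what the source reports. "The series", "measured", "known", "first", "only" and "open" are said of these compounds alone.

Working notes on the series. The shared core is that of compound 1 `OC[C@H]1O[C@@H](n2cnc3c(NCc4ccccc4Br)ncnc32)[C@H](O)[C@@H]1O`. In a functional assay on G-361 cells (Homo sapiens) for antiproliferative activity, with a stated time of 72 h (a higher number here means a weaker inhibitor, a lower number a stronger inhibitor), compound 1 returns only a limit, > 166000 nM. Compound 2 `COc1ccccc1CNc1ncnc2c1ncn2[C@@H]1O[C@H](CO)[C@@H](O)[C@H]1O` likewise gives only a limit in this assay, > 166000 nM. Going by the values given here, compound 3 `OC[C@H]1O[C@@H](n2cnc3c(NCc4ccc(Cl)c(Cl)c4)ncnc32)[C@H](O)[C@@H]1O` is the one member with a number, 145000 nM. The step that the two limits leave unreadable from compound 1 to compound 2 cannot be read. The steps of an at least 1.1-fold lower number from compound 1 to compound 3 (0.05 log units; that floor lies within the scatter) and an at least 1.1-fold lower number from compound 2 to compound 3 (0.05 log units; that floor lies within the scatter) stay within the scatter, and the limit of > 166000 nM in this assay, at which 2 of the 3 values shown sit, marks where most values sit. Compound 4 `Cc1ccc(O)c(CNc2ncnc3c2ncn3[C@@H]2O[C@H](CO)[C@@H](O)[C@H]2O)c1` differs from compound 1 by 2-hydroxy-5-methylphenyl in place of 2-bromophenyl on a saturated chain carbon bound to a nitrogen on an aromatic ring. Given an at least 1.1-fold lower number from compound 1 to compound 3 (0.05 log units; that floor lies within the scatter) and an at least 1.1-fold lower number from compound 2 to compound 3 (0.05 log units; that floor lies within the scatter), both within the scatter, no shift beyond the scatter is expected for compound 4 in this assay. Compound 4 is therefore expected near 160000 nM, between 70000 nM and 400000 nM, probably again as a limit, a step of an at least 1.0-fold lower number from compound 1 to compound 4 (0.01 log units; that floor lies within the scatter).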

Compound 4, half-maximal inhibitory concentration: > 166000 nM
Compound 4: only a limit was reported; the forecaster's own chance of this, stated with the estimate: 75%; middle value at least 1.0-fold (0.01 log units) away from the limit.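

In this assay the 2-hydroxy-5-methylphenyl group, with its hydrogen-bond donor and acceptor in this place, gives compound 4 only a limit, so the steps from compound 1 and compound 2 cannot be read. Going by these compounds alone, the one readable step is an at least 1.1-fold higher number from compound 3 to compound 4 (0.05 log units; that floor lies within the scatter) and it stays within the scatter. Replacing the halogen or methoxy substitution with this hydroxy and methyl pattern therefore opens no measurable difference, and the series remains gathered at one limit: the limit of > 166000 nM in this assay, at which 3 of the 4 values shown sit.

On these data alone, whether any group in this place moves a value beyond the scatter stays open. An amine, a carboxylic acid or a longer chain there could settle that.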